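The compounds below may be only part of what the source reports. "The series", "measured", "known", "first", "only" and "open" are said of these compounds alone.

Values in a functional assay on SK-BR-3 cells (Homo sapiens) for antiproliferative activity; a higher number here means a weaker inhibitor, a lower number a stronger inhibitor:
- compound 1 `CC(=O)Oc1ccc(C(=O)Nc2cc3ccc(OCCC4CCCCN4)c(C)c3oc2=O)cc1CC=C(C)C`: 640 nM
- compound 2 `CC(C)=CCc1cc(C(=O)Nc2cc3ccc(OCCCN4CCCCC4)c(C)c3oc2=O)ccc1O`: > 50000 nM (a limit of the assay)
- compound 3 `CC(C)=CCc1cc(C(=O)Nc2cc3ccc(OCCCN4CCCC4)c(C)c3oc2=O)ccc1O`: 720 nM

Compound 3, at 720 nM, lies within the scatter of compound 1 at 640 nM. The only other entry is the limit held by compound 2.

Compound 4 `CC(C)=CCc1cc(C(=O)Nc2cc3ccc(OCCCNCC(C)C)c(C)c3oc2=O)ccc1O` is the next point on the series. Its difference from compound 3 is isobutylamino in place of pyrrolidin-1-yl on a saturated chain carbon, three bonds along the chain from an oxygen on an aromatic ring.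

Going by the values given here, one measured step bears on this place: an at least 69-fold lower number from compound 2 to compound 3 (1.84 log units; beyond the scatter). That step is large, and one of its ends is a limit. It shows that this assay can respond sharply to an exchange of amine at this place, though it is a single pair and concerns two ring amines, not an open chain. Among the compounds with values here, compound 1 differs from compound 3 in more than one place and gives no step here.

A move to a higher number, beyond the scatter but smaller than the measured step, is therefore expected, with wide uncertainty. The expected step is a 3.5-fold higher number from compound 3 to compound 4 (0.54 log units; beyond the scatter). For compound 4 the estimated value is 2500 nM, with an expected range of 500 nM to 25000 nM.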

Compound 4, half-maximal inhibitory concentration: 1030 nM
Beside the measured number, compound 4's estimate is 2.4-fold (0.39 log units) above it, and the stated range covers the measured number.
By their numbers in this assay, from the lowest: compounds 1, 3 and 4 (each within the scatter of the next). At a limit, above all of these: compound 2.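

In this assay, the exchange of pyrrolidin-1-yl for isobutylamino gives a 1.4-fold higher number from compound 3 to compound 4 (0.16 log units; within the scatter), so in this pair the amine at this place need not be a ring, and the hydrogen-bond donor that enters with isobutylamino leaves no readable mark on the value. The sharp response seen earlier therefore does not follow a simple divide between ring amines and open-chain amines, since one ring amine and the open-chain amine both stand far from piperidin-1-yl, with an at least 48-fold lower number from compound 2 to compound 4 (1.68 log units; beyond the scatter) alongside the earlier at least 69-fold lower number from compound 2 to compound 3 (1.84 log units; beyond the scatter). Compound 2 holds a limit rather than a number, so the true size of each step from it remains unknown: the limit of > 50000 nM in this assay, at which 1 of the 4 values shown sits.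

The compounds shown do not settle whether the loss belongs to piperidin-1-yl alone or extends to other six-membered ring amines, such as morpholin-4-yl or 4-methylpiperazin-1-yl. They also leave open how far the tolerance for open-chain amines reaches, for example to a primary amine, dimethylamino or a bulkier tert-butylamino group, and whether it holds on a shorter ethyl chain or a longer butyl chain.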